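Swapping the aryl group on the shared core

The compounds below may be only part of what the source reports. "The series", "measured", "known", "first", "only" and "open" are said of these compounds alone.

Compound 2 `CNC(=O)c1cc(Oc2ccc(NC(=O)c3cc4cccnc4n(-c4ccc(OC)cc4)c3=O)cc2)ccn1` carries a 4-methoxyphenyl group on the aromatic nitrogen of the shared core. Within the data shown here, in a functional assay on HT-29 cells (Homo sapiens) for antiproliferative activity, read by MTT assay, with a stated time of 72 h (a higher number here means a weaker inhibitor, a lower number a stronger inhibitor), compound 2 gives 920 nM, the higher of the two numbers measured so far. Its nearest neighbour is compound 1 `CNC(=O)c1cc(Oc2ccc(NC(=O)c3cc4cccnc4n(-c4ccccc4F)c3=O)cc2)ccn1`, which in this assay gives 260 nM. Among the measured compounds shown here, the one step between them is a 3.5-fold higher number from compound 1 to compound 2 (0.55 log units; beyond the scatter). Compound 3 `CNC(=O)c1cc(Oc2ccc(NC(=O)c3cc4cccnc4n(-c4ccc(Br)cc4F)c3=O)cc2)ccn1` has not yet been measured; it differs from compound 2 by 4-bromo-2-fluorophenyl in place of 4-methoxyphenyl on an aromatic nitrogen. The step from compound 1 to compound 2 bears directly on this change. Compound 3 brings back the 2-fluorophenyl arrangement of compound 1, now carrying an extra bromine, and that earlier step was a 3.5-fold higher number from compound 1 to compound 2 (0.55 log units; beyond the scatter). The expected step is therefore a decrease, a 3.1-fold lower number from compound 2 to compound 3 (0.49 log units; beyond the scatter), with the bromine adding uncertainty. For compound 3 the estimated value is 300 nM, within a range from 100 nM to 900 nM.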

Compound 3, half-maximal inhibitory concentration: 1950 nM
Estimate against measurement, compound 3: 6.5-fold (0.81 log units) below, outside the stated range (above it).
By their numbers in this assay, from the lowest: compound 1; then compound 2; then compound 3.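

Putting a bromo in place of hydrogen on the 2-fluorophenyl group weakens the result in this assay (a 7.5-fold higher number from compound 1 to compound 3 (0.88 log units; beyond the scatter)), so this position does not tolerate every addition to that group. The 2-fluorophenyl arrangement alone therefore does not secure a low number, and 4-bromo-2-fluorophenyl in place of 4-methoxyphenyl also moves the number upward (a 2.1-fold higher number from compound 2 to compound 3 (0.33 log units; beyond the scatter)), so the groups carrying fluorine now give both the lowest and the highest of the three numbers. No measurement shown explains these shifts.

A 2-fluoro-4-methoxyphenyl group would help separate the contributions of fluoro and methoxy on this ring. From the compounds shown here alone, how an amine or a carboxylic acid in place of the bromine would behave also remains open.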